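Compound 2 to compound 3: methoxy in place of chloro

This account rests on a few compounds, and the source may have more. Where it says the series, first, only, none or still open, it means among the compounds named here.

Compound 1 `COc1ccc(/C=C2\CCC/C(=C\c3ccc(OC)c(OC)c3)C2=O)cc1OC`: 8500 nM
Compound 2 `COc1ccc(/C=C2\CCC/C(=C\c3ccc(O)c(Cl)c3)C2=O)cc1OC`: > 20000 nM

Both compounds were tested in a functional assay on A549 cells (Homo sapiens) for cytotoxicity, read by MTT assay, with a stated time of 72 h; on this read-out higher numbers stand for weaker inhibition and lower numbers for stronger inhibition. There, compound 1 gives 8500 nM.

In this assay, compound 2 stands at > 20000 nM, which is a limit of the assay and not a number.

Compound 3 `COc1cc(/C=C2\CCC/C(=C\c3ccc(OC)c(OC)c3)C2=O)ccc1O` has not yet been measured. It differs from compound 2 by methoxy in place of chloro on an aromatic carbon, with methoxy in place of chloro on an aromatic carbon, ortho to a hydroxy group. The same difference reads 3-chloro-4-hydroxyphenyl to 4-hydroxy-3-methoxyphenyl.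

For the measured compounds named here, no measured step shows this change directly. The expectation leans on compound 1 at 8500 nM, which also carries methoxy groups and no chloro. The expected change, towards stronger inhibition, is an at least 2.2-fold lower number from compound 2 to compound 3 (0.34 log units; beyond the scatter). For compound 3 the estimated value is 9000 nM, with an expected range of 3500 nM to 20000 nM.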

Compound 3, half-maximal inhibitory concentration: 10300 nM
Estimate against measurement, compound 3: 1.1-fold (0.06 log units) below; measured number inside the range.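

In this assay, compound 2 stands at > 20000 nM, which is a limit of the assay and not a number. Methoxy in place of chloro, ortho to a hydroxy group, now gives an at least 1.9-fold lower number from compound 2 to compound 3 (0.28 log units; that floor lies within the scatter), and the true size of this step cannot be read from a floor set by that limit: the limit of > 20000 nM in this assay, at which 1 of the 3 values shown sits. Hydrogen in place of methyl on an oxygen on an aromatic ring gives a 1.2-fold higher number from compound 1 to compound 3 (0.08 log units; within the scatter), so in this assay the hydroxy group of compound 3 and the matching methoxy group of compound 1 cannot be told apart.

As far as these compounds go, how far compound 2 truly lies from compound 3 stays open. So does whether an amine or a carboxylic acid on the same aromatic carbon would shift the number beyond the scatter.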